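The source may report more compounds than this note shows. Statements on the series, on what has been measured and on what is new or still open speak of the compounds shown alone.

Compound 2, with the structure `CC(C(=O)NCc1ccc(C(F)(F)F)nc1N(C(C)C)S(=O)(=O)c1ccccc1)c1ccc(NS(C)(=O)=O)c(F)c1`, gives 410 nM in an assay on CHO cells for displacement of a labelled ligand from transient receptor potential cation channel subfamily V member 1 (Homo sapiens), read by scintillation counting, with a stated time of 60 min (on this read-out lower numbers stand for stronger inhibition and higher numbers for weaker inhibition), and among the two compounds measured it holds the lowest number there. Its nearest neighbour is compound 1, `CC(C(=O)NCc1ccc(C(F)(F)F)nc1N(C)S(=O)(=O)c1ccccc1)c1ccc(NS(C)(=O)=O)c(F)c1`, which in this assay gives 698 nM. These two differ only in the group on the sulfonamide nitrogen, and the step of a 1.7-fold lower number from compound 1 to compound 2 (0.23 log units; within the scatter) lies within the scatter, so the two values cannot be ranked.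

Compound 3, `CC(C(=O)NCc1ccc(C(F)(F)F)nc1N(CC1CCCCC1)S(=O)(=O)c1ccccc1)c1ccc(NS(C)(=O)=O)c(F)c1`, carries the change (cyclohexylmethyl in place of isopropyl on a sulfonamide nitrogen). For the measured compounds named here, the only measured step that bears on it is a 1.7-fold lower number from compound 1 to compound 2 (0.23 log units; within the scatter), a move from a small group to a slightly larger one on the same nitrogen that produced no shift beyond the scatter. The step to compound 3 enlarges that group again, from isopropyl to cyclohexylmethyl, but the measured data contain nothing larger than isopropyl at this position, so no firm direction can be read. A step no larger than the scatter is expected in this assay, with the number for compound 3 estimated at 300 nM, between 100 nM and 900 nM, corresponding to a 1.4-fold lower number from compound 2 to compound 3 (0.14 log units; within the scatter).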

Compound 3, inhibition constant: 2.3 nM
Compound 3: the middle estimate sits 130-fold (2.12 log units) above what was measured; measured number outside the range, below it.
By their numbers in this assay, from the lowest: compound 3; then compounds 2 and 1 (each within the scatter of the next).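

In this assay, the group on the sulfonamide nitrogen proves to be a place where the number can move a long way: the earlier step, a 1.7-fold lower number from compound 1 to compound 2 (0.23 log units; within the scatter), gave no readable change, whereas the new data show a 180-fold lower number from compound 2 to compound 3 (2.25 log units; beyond the scatter) and a 300-fold lower number from compound 1 to compound 3 (2.48 log units; beyond the scatter) as large steps. Compound 3 is therefore the strongest of the compounds shown, and the range at this position reaches far beyond what methyl and isopropyl suggested. The change from isopropyl to cyclohexylmethyl adds carbon atoms and a six-membered non-aromatic ring of carbon only, with no hydrogen-bond donor, hydrogen-bond acceptor or net charge on either side, and nothing measured here accounts for the size of the shift.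

As far as these compounds go, it remains open whether the ring or simply the larger count of carbon atoms goes with the low number, which an open chain such as n-heptyl on the same nitrogen would help to separate. Also open, from the compounds shown here alone, is how the number would respond to a benzyl group, or to a piperidinylmethyl group, which would bring an amine into the ring.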